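Cytotoxicity of a chloro-substituted phenoxy analogue

The compounds below may be only part of what the source reports. "The series", "measured", "known", "first", "only" and "open" are said of these compounds alone.

Of the compounds shown here, three built on a shared core have been tested in an ADME assay on MRC5 cells (Homo sapiens) for cytotoxicity, read by fluorescence and resazurin assay, with a stated time of 3 days; on this read-out lower numbers stand for stronger inhibition and higher numbers for weaker inhibition. Compound 1 `Cc1cn(C2CCN(Cc3cccc(Oc4cc(F)cc(F)c4)c3)CC2)c(=O)[nH]c1=O` gives > 64000 nM, which is a limit of the assay rather than a number. Compound 2 `Cc1cn(C2CCN(Cc3cccc(Oc4ccccc4)n3)CC2)c(=O)[nH]c1=O` also gives a limit, > 64000 nM. Compound 3 `Cc1cn(C2CCN(Cc3cncc(Oc4ccccc4)c3)CC2)c(=O)[nH]c1=O` likewise gives only a limit, > 64000 nM. All three sit at the same limit, as the limit of > 64000 nM in this assay, at which 3 of the 3 values shown sit, shows, so none of them shows measurable toxicity toward these cells within the tested range, and no ordering among them can be read from the numbers.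

Compound 4 `Cc1cn(C2CCN(Cc3cncc(Oc4cccc(Cl)c4)c3)CC2)c(=O)[nH]c1=O` has not yet been measured in this assay. It differs from compound 3 in one place: chloro in place of hydrogen on an aromatic carbon. With every measured compound sitting at the limit, the step from compound 3 to compound 4 is expected to be none beyond the usual scatter, which is what a step that the limit leaves unreadable from compound 3 to compound 4 expresses. Compound 4 is therefore expected to give about 80000 nM, within a range of 30000 nM to 200000 nM, most probably reported again as a limit.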

Compound 4, half-maximal inhibitory concentration: > 64000 nM
Compound 4 gave a limit, no number; the forecaster's own chance of this, stated with the estimate: 85%; the middle value does not contradict the limit.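

Compound 3 and compound 4 both give only a limit rather than a number, so the effect of chloro in place of hydrogen cannot be read: the limit of > 64000 nM in this assay, at which 4 of the 4 values shown sit.

The compounds shown leave open at what concentration, if any, each would become toxic to these cells.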